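The source may report more compounds than this note shows. Statements on the series, on what has been measured and on what is new or still open speak of the compounds shown alone.

Measured so far in an in vitro ADME assay on the whole organism (microsomes, liver, Mus musculus) for metabolic stability, read by LC-MS, with a stated time of 24 h, at a dose of 5 mg/kg by the intravenous route; on this read-out lower numbers stand for a shorter-lived compound and higher numbers for a longer-lived compound:
- compound 1 `O=[N+]([O-])c1cn2c(n1)OC[C@@H](NCc1ccc(OC(F)(F)F)c(Oc3ccccc3)c1)C2` gives 0.155 h
- compound 2 `O=[N+]([O-])c1cn2c(n1)OC[C@@H](NCc1ccc(OC(F)(F)F)cc1F)C2` gives 0.242 h
- compound 3 `O=[N+]([O-])c1cn2c(n1)OC[C@@H](NCc1ccc(OC(F)(F)F)c(F)c1)C2` gives 0.393 h

Compound 2 lies within the scatter of both compound 1 and compound 3 in this assay, and only those two stand apart (a 2.5-fold higher number from compound 1 to compound 3 (0.40 log units; beyond the scatter)). Compound 4 `O=[N+]([O-])c1cn2c(n1)OC[C@@H](NCc1ccc(OC(F)(F)F)cc1Cl)C2` carries chloro in place of fluoro on an aromatic carbon, ortho to a large group (chloro in place of fluoro on an aromatic carbon). Among the compounds with values here, no measured step makes this exchange. Within the data shown here, the one measured step puts fluoro in place of phenoxy, a different exchange, so it gives only a loose guide to size. No shift in either direction beyond the scatter is expected. The expected change is a 1.1-fold lower number from compound 2 to compound 4 (0.04 log units; within the scatter) and no more. For compound 4 the estimated half-life is 0.22 h, with an expected range of 0.11 h to 0.43 h.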

Compound 4, half-life: 0.332 h
Compound 4: the middle estimate sits 1.5-fold (0.18 log units) below what was measured; the measured number falls inside the stated range.
By their numbers in this assay, from the lowest: compounds 1, 2, 4 and 3 (each within the scatter of the next, the first and the last beyond it).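

Working note: in this assay, chloro in place of fluoro on the aromatic carbon ortho to a large group gives (a 1.4-fold higher number from compound 2 to compound 4 (0.14 log units; within the scatter)). This is the only exchange shown at this position, and on half-life it does not separate the two halogens. No measurement shown accounts for this result.

Open, on these data alone, is whether a nitrile, a methoxy group or an amine on the same carbon would stand apart from fluoro and chloro. Also open, as far as these compounds go, is whether the same exchange reads alike on the other aromatic carbons.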